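A few compounds are considered here, and "the series" means these few. Any claim that something is new, unique, unknown or untested is made for them only; others in the source may bear on it.

Measured compounds:
compound 1, `CC1=C(C(=O)Nc2ccc(F)cc2)C(c2ccc([N+](=O)[O-])cc2)N=C(SCc2ccccc2)N1`, 23.7%
compound 2, `CC1=C(C(=O)Nc2ccc(F)cc2)C(c2ccc([N+](=O)[O-])cc2)N=C(SCc2ccc(Cl)cc2)N1`, 23.2%
compound 3, `CC1=C(C(=O)Nc2ccc(Br)cc2)C(c2ccc(Cl)cc2Cl)N=C(SCc2ccccc2)N1`, 13.4%

Of the compounds shown here, three have been tested in a functional assay on the whole organism (artery, strain albino) with Rattus norvegicus as the target, with a stated time of 180 min, at a dose of 10 mg/kg by the oral route; on this read-out higher numbers stand for more inhibition at the one dose given (going by the name of the read-out) and lower numbers for less inhibition. In this assay compound 1 gives 23.7%, and compound 2 gives 23.2%. Compound 2 differs from compound 1 by chloro in place of hydrogen on an aromatic carbon, and that change gave a number 0.5 percentage points lower from compound 1 to compound 2 (within the scatter). Compound 3 gives 13.4% in this assay; its value lies beyond the scatter from that of compound 1, but within the scatter of that of compound 2. The difference between the core of compound 3 and the core of compound 1 is not broken down here.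

Compound 4, `CC1=C(C(=O)Nc2ccc(Br)cc2)C(c2ccc(Cl)cc2Cl)N=C(SCc2ccccc2Cl)N1`, has not yet been measured. It differs from compound 3 by chloro in place of hydrogen on an aromatic carbon. This is the same kind of change as that from compound 1 to compound 2, but not the same: in compound 2 the chloro sits para to a large group, whereas in compound 4 it sits ortho to a large group. Among the compounds with values here, the only measured step of this kind, from compound 1 to compound 2, stayed within the scatter, and that is the sole basis for the expectation here. Compound 4 is therefore expected to give a value close to that of compound 3, with an estimated step of a number 0.4 percentage points lower from compound 3 to compound 4 (within the scatter). The estimate for compound 4 in this assay is 13%, with a range from 3% to 24%, though the change of place from para to ortho leaves room for a different outcome.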

Compound 4, a percentage reported as inhibition, in the whole organism at one dose (the size of the read-out at that dose, not a potency): 22.2%
For compound 4 the middle estimate is 9.2 percentage points below the measured one, within the range that was stated.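

In this assay, the new pair gives a number 8.8 percentage points higher from compound 3 to compound 4 (within the scatter), where benzylsulfanyl becomes (2-chlorobenzyl)sulfanyl, while the earlier pair, with a chloro on the benzyl group of a different core, gave a number 0.5 percentage points lower from compound 1 to compound 2 (within the scatter). Set side by side, the two steps do not differ by more than the scatter of such steps allows, so nothing here speaks against carrying this change from one core to the other: the same change on two cores in this assay, a number 0.5 percentage points lower (within the scatter) from compound 1 to compound 2 and a number 8.8 percentage points higher (within the scatter) from compound 3 to compound 4, 9.3 percentage points apart, within the scatter of two such steps. Within the data shown here, this does not show that the change has the same effect on both cores, since there are only two pairs, neither step lies beyond the scatter, and the chloro stands in a different place in each pair, which means that the place of the chloro and the core cannot be told apart.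

The compounds shown leave open how a 2-chlorobenzyl group would read on the core of compound 1, which would keep the place of the chloro fixed while only the core changed. They also leave open what this assay would show with a longer chain in place of the benzyl group, or with an amine or a carboxylic acid on it.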